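The compounds below may be only part of what the source reports. "The series", "measured", "known", "first", "only" and "open" are said of these compounds alone.

Measured compounds:
compound 1 `COc1ccccc1-c1cc(O)c2cc(C)cnc2n1` gives 4470 nM
compound 2 `Cc1cc(C)c2c(O)cc(-c3ccc(Cl)cc3)nc2n1` gives 3630 nM
compound 3 `COc1ccccc1-c1cc(O)c2cccnc2n1` gives 20000 nM

These three values come from a functional assay on MDA-N cells (Homo sapiens); a higher number here means a weaker inhibitor of growth, a lower number a stronger inhibitor of growth. Compound 2 has the lowest of the three numbers; its nearest neighbour is compound 1, whose value lies within the scatter of that of compound 2, while compound 3 lies well beyond it. Within the data shown here, the only measured step is a 4.5-fold higher number from compound 1 to compound 3 (0.65 log units; beyond the scatter), which concerns the shared core and not the ring that carries the halogen.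

Compound 4 `COc1ccc(-c2cc(O)c3c(C)cc(C)nc3n2)cc1` is not yet measured. It differs from compound 2 in one place: methoxy in place of chloro on an aromatic carbon. Among the measured compounds shown here, no measured step in this set touches that position, so nothing here shows how a chloro and a methoxy compare in this assay. The expectation therefore rests on compound 2 alone, with its value of 3630 nM, and on the fact that changes elsewhere in this set were at most modest. A step of a 1.4-fold higher number from compound 2 to compound 4 (0.14 log units; within the scatter) is expected, which would not go clearly beyond the scatter. For compound 4 the estimated value is 5000 nM, with a range from 1800 nM to 14000 nM.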

Compound 4, concentration for 50% growth inhibition: 33100 nM
Compound 4: the middle estimate sits 6.6-fold (0.82 log units) below what was measured, and the stated range ends below it.
By their numbers in this assay, from the lowest: compounds 2 and 1 (each within the scatter of the next); then compounds 3 and 4 (each within the scatter of the next).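

In this assay, replacing chloro with methoxy on this aromatic carbon, para to a large group, gives a 9.1-fold higher number from compound 2 to compound 4 (0.96 log units; beyond the scatter) and so weakens growth inhibition. Among these compounds, the earlier compounds showed a measured change only in the shared core, with a 4.5-fold higher number from compound 1 to compound 3 (0.65 log units; beyond the scatter) as their single step, so this is the first evidence that the ring carrying the halogen also matters and that the group at this place can move the number beyond the usual scatter. Nothing measured on these compounds gives a reason for this change, and one pair of groups cannot separate the effect of removing chloro from the effect of adding methoxy.

What the compounds shown leave open is how other groups would behave at this same place: a plain hydrogen, a fluoro, an amine or a longer chain such as ethoxy could fall close to compound 2, close to compound 4 or elsewhere. On these data alone, it also remains open whether the swap from chloro to methoxy would produce a similar step on the core of compound 3, which has no methyl groups on its core.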